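Adding a methyl to compound 2

This account rests on a few compounds, and the source may have more. Where it says the series, first, only, none or still open, it means among the compounds named here.

Measured so far:
- compound 1 `COc1cc(/C=C/C(=O)/C=C/c2nc3cc([N+](=O)[O-])ccc3n2C)ccc1O`: 3700 nM
- compound 2 `COc1ccc(/C=C/C(=O)/C=C/c2nc3ccccc3n2C)cc1O`: 2900 nM

Both values come from a functional assay on HepG2 cells (Homo sapiens) for cytotoxicity, read by MTT assay, with a stated time of 48 h; a lower number here means a stronger inhibitor, a higher number a weaker inhibitor. Compound 2 lies within the scatter of compound 1, so these two numbers set no order. Compound 3 `COc1ccc(/C=C/C(=O)/C=C/c2nc3cc(C)ccc3n2C)cc1O` differs from compound 2 by methyl in place of hydrogen on an aromatic carbon. For the measured compounds named here, no step between measured compounds informs this change, so no shift beyond the scatter is expected in this assay, and neither direction is favoured. The expected step is a 1.0-fold lower number from compound 2 to compound 3 (0.02 log units; within the scatter). For compound 3 the estimated value is 2800 nM, within an expected range of 1200 nM to 6500 nM.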

Compound 3, half-maximal inhibitory concentration: 3300 nM
Estimate against measurement, compound 3: 1.2-fold (0.07 log units) below, and the stated range covers the measured number.
By their numbers in this assay, from the lowest: compounds 2, 3 and 1 (each within the scatter of the next).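

For the compounds shown here, the first step, methyl in place of hydrogen on an aromatic carbon, reads in this assay as a 1.1-fold higher number from compound 2 to compound 3 (0.06 log units; within the scatter) and so sets no order between the two compounds. This carbon of the shared core therefore accepts a methyl with no readable shift in this assay. Nothing measured here gives a reason for this result.

As far as these compounds go, whether an amine or a carboxylic acid on this same carbon would shift the number beyond the scatter stays open. A single step also leaves open whether a longer chain, such as propyl, would behave as methyl does.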